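Lengthening the Hydroxyalkyl Chain

The source may report more compounds than this note shows. Statements on the series, on what has been measured and on what is new or still open speak of the compounds shown alone.

Compound 1 `OCc1cn(CCNc2nonc2/C(=N/O)Nc2ccc(F)c(Br)c2)nn1` gives 77 nM in an assay on isolated protein for inhibition of Indoleamine 2,3-dioxygenase 1 (Homo sapiens); a higher number here means a weaker inhibitor, a lower number a stronger inhibitor.
Compound 2 `OCCc1cn(CCNc2nonc2/C(=N/O)Nc2ccc(F)c(Br)c2)nn1` gives 247 nM in this assay.

Among these two numbers compound 2 stands at the higher one, which in this assay means the weaker inhibitor; the only measured step, a 3.2-fold higher number from compound 1 to compound 2 (0.51 log units; beyond the scatter), was a modest weakening on adding a carbon to the hydroxyalkyl chain. Compound 3 `OCCCc1cn(CCNc2nonc2/C(=N/O)Nc2ccc(F)c(Br)c2)nn1` differs from compound 2 by hydroxymethyl in place of hydroxy on a saturated chain carbon, two bonds along the chain from an aromatic carbon, in other words the same kind of lengthening applied once more, one bond further out. Among the measured compounds shown here, the step of a 3.2-fold higher number from compound 1 to compound 2 (0.51 log units; beyond the scatter) is the sole guide here, and it points toward a further rise in the number, though a second lengthening need not cost as much as the first. The expected step is therefore a 1.7-fold higher number from compound 2 to compound 3 (0.23 log units; within the scatter), a weakening somewhat smaller than the measured one. Compound 3 is estimated at 420 nM, within a range of 160 nM to 1200 nM.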

Compound 3, half-maximal inhibitory concentration: 98 nM
Compound 3: middle estimate off by 4.3-fold (0.63 log units), on the high side, and the stated range ends above it.
By their numbers in this assay, from the lowest: compounds 1 and 3 (each within the scatter of the next); then compound 2.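

Lengthening the chain does not push the result in one direction at this position: in this assay the change from 2-hydroxyethyl to 3-hydroxypropyl gives a 2.5-fold lower number from compound 2 to compound 3 (0.40 log units; beyond the scatter) and so reverses the earlier weakening, even though the same kind of lengthening was made. Setting the shortest chain against the longest gives a 1.3-fold higher number from compound 1 to compound 3 (0.10 log units; within the scatter) and thus no real difference between hydroxymethyl and 3-hydroxypropyl, so among these three only compound 2, with its 2-hydroxyethyl group, stands apart. No measurement is available that would explain why the number rises and then falls along this series.

Going by these compounds, whether a longer chain, such as 4-hydroxybutyl, would continue this up-and-down pattern remains open. Also open, on these data alone, is how the number would respond if an amine or a carboxylic acid took the place of the hydroxy group.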